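Series notes: naphthalen-2-yl in place of 4-chlorophenyl

This account rests on a few compounds, and the source may have more. Where it says the series, first, only, none or still open, it means among the compounds named here.

The compounds share one core and differ in the group on an amide-type nitrogen in a ring. In a functional assay, with a stated time of 20 min (on this read-out lower numbers stand for stronger inhibition and higher numbers for weaker inhibition), compound 1 `CC(C)[C@@H]1CC[C@@H](C)C[C@@]12N(C)C(=O)[C@@H]1[C@H]3C(=O)N(c4ccccc4)C(=O)[C@H]3ON12` gives 900 ug/mL, compound 2 `CC(C)[C@@H]1CC[C@@H](C)C[C@@]12N(C)C(=O)[C@@H]1[C@H]3C(=O)N(c4ccc(Cl)cc4)C(=O)[C@H]3ON12` gives 2150 ug/mL and compound 3 `COc1ccc(N2C(=O)[C@H]3[C@H](ON4[C@@H]3C(=O)N(C)[C@@]43C[C@H](C)CC[C@H]3C(C)C)C2=O)cc1` gives 1120 ug/mL. Compound 2 stands at the upper end of these numbers: a 2.4-fold higher number from compound 1 to compound 2 (0.38 log units; beyond the scatter) is a modest step beyond the scatter, whereas a 1.9-fold lower number from compound 2 to compound 3 (0.28 log units; within the scatter) stays within it.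

Compound 4 `CC(C)[C@@H]1CC[C@@H](C)C[C@@]12N(C)C(=O)[C@@H]1[C@H]3C(=O)N(c4ccc5ccccc5c4)C(=O)[C@H]3ON12` carries the next change: naphthalen-2-yl in place of 4-chlorophenyl on an amide-type nitrogen in a ring. For the measured compounds named here, no measured step makes this exchange. The three available steps are all replacements on an aromatic carbon of that group. Besides the two above, a 1.2-fold higher number from compound 1 to compound 3 (0.09 log units; within the scatter) also lies within the scatter. These steps are small, but none of them tests a second aromatic ring, so they offer only weak guidance. With compound 2 at 2150 ug/mL at the upper end of a narrow span, a slight move down is judged more likely than a rise. The expected change is a 1.3-fold lower number from compound 2 to compound 4 (0.13 log units; within the scatter), so no step beyond the scatter is expected. Compound 4 is estimated at 1600 ug/mL, with an expected range from 750 ug/mL to 3400 ug/mL.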

Compound 4, half-maximal inhibitory concentration: 2920 ug/mL
Compound 4: middle estimate off by 1.8-fold (0.26 log units), on the low side, within the range that was stated.
By their numbers in this assay, from the lowest: compounds 1, 3, 2 and 4 (each within the scatter of the next, the first and the last beyond it).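

In this assay, for the compounds shown here, the first group at this nitrogen with 2 six-membered aromatic rings does not separate from the 4-chlorophenyl group, as a 1.4-fold higher number from compound 2 to compound 4 (0.13 log units; within the scatter) shows, so adding a second ring in place of the chlorine leaves compound 4 and compound 2 indistinguishable on this read-out. The naphthalen-2-yl group does separate from the other two groups, with a 2.6-fold higher number from compound 3 to compound 4 (0.42 log units; beyond the scatter) and with a 3.2-fold higher number from compound 1 to compound 4 (0.51 log units; beyond the scatter) as modest steps, so this position tolerates the larger aromatic group without any gain and with a measurable move towards weaker inhibition against the phenyl and 4-methoxyphenyl groups. No measured information bearing on the reason for these differences is available.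

As far as these compounds go, all four groups at this position are carbon-only aromatic rings, so it remains open how a benzyl group, a straight alkyl chain, or a phenyl ring carrying an amine or a carboxylic acid would read here. Also open, from the compounds shown here alone, is whether any change at this nitrogen can bring the number clearly below that of compound 1 at 900 ug/mL, or whether stronger inhibition must come from elsewhere on the shared core.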